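A few compounds are considered here, and "the series" means these few. Any claim that something is new, unique, unknown or untested is made for them only; others in the source may bear on it.

Measured so far in an in vitro assay on BTI-TN-5B1-4 cells for inhibition of Amine oxidase [flavin-containing] B (Homo sapiens), read by fluorescence; a higher number here means a weaker inhibitor, a lower number a stronger inhibitor:
- compound 1 `O=C(Nc1ccccc1Cc1ccccc1)c1cc2ccccc2oc1=O` gives 910 nM
- compound 2 `Cc1ccc(NC(=O)c2cc3ccccc3oc2=O)cc1` gives 710 nM
- compound 3 `CSc1ccc(NC(=O)c2cc3ccccc3oc2=O)cc1` gives 2840 nM

Compound 2 holds the lowest of the three numbers, but compound 1 sits within the scatter of it; only compound 3 stands apart, by a 4.0-fold higher number from compound 2 to compound 3 (0.60 log units; beyond the scatter).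

Compound 4 `O=C(Nc1ccc(O)cc1)c1cc2ccccc2oc1=O` is the next variation: hydroxy in place of methyl on an aromatic carbon. Going by the values given here, the one measured step that touches the same methyl is the exchange for methylsulfanyl, from compound 2 to compound 3, a modest loss. Among the compounds with values here, no measured pair shows a hydroxy, so the direction for compound 4 is open. A step of at most the size seen there is expected, with the change a 1.4-fold higher number from compound 2 to compound 4 (0.15 log units; within the scatter) taken as the working guess. Compound 4 is estimated at 1000 nM, in the range 400 nM to 3000 nM.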

Compound 4, half-maximal inhibitory concentration: 800 nM
Beside the measured number, compound 4's estimate is 1.3-fold (0.10 log units) above it; low and high end bracket the measured number.
By their numbers in this assay, from the lowest: compounds 2, 4 and 1 (each within the scatter of the next); then compound 3.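

In this assay, the position para to a large group takes hydroxy in place of methyl with the two values within the scatter (a 1.1-fold higher number from compound 2 to compound 4 (0.05 log units; within the scatter)). The loss seen with methylsulfanyl therefore does not extend to every replacement of methyl here, and hydroxy stands clearly apart from methylsulfanyl (a 3.6-fold lower number from compound 3 to compound 4 (0.55 log units; beyond the scatter)). No evidence is available on what lies behind these differences.

From the compounds shown here alone, whether an amine, a methoxy group or a carboxylic acid at this position would track hydroxy or methylsulfanyl remains open.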